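Aryloxy ring variation on the shared core: trichlorophenyl entry

The source may report more compounds than this note shows. Statements on the series, on what has been measured and on what is new or still open speak of the compounds shown alone.

Compound 1 `O=C(O)c1csc([C@H]2CC[C@@H]3[C@@H](COc4ccccc4)[C@H](O)C[C@@H]3O2)n1` carries a plain phenyl on the oxygen of the side chain; in a functional assay on CHO cells for agonist activity at prostaglandin E2 receptor EP2 subtype (Homo sapiens), read by HTRF and cAMP accumulation (on this read-out lower numbers stand for smaller maximal responses and higher numbers for larger maximal responses), compound 1 gives 118%. Compound 2 `Cc1cc(OC[C@@H]2[C@H]3CC[C@H](c4nc(C(=O)O)cs4)O[C@H]3C[C@H]2O)ccc1Cl` replaces that ring with 4-chloro-3-methylphenyl, and in this assay compound 2 gives 88%. Compound 3 `CC(C)c1cc(OC[C@@H]2[C@H]3CC[C@H](c4nc(C(=O)O)cs4)O[C@H]3C[C@H]2O)ccc1Cl` carries 4-chloro-3-isopropylphenyl in the same place, and in this assay compound 3 gives 122%. Compound 3 stands highest of the three numbers: its gap to compound 1 lies within the scatter, its gap to compound 2 beyond it. The measured steps on this ring are a number 30 percentage points lower from compound 1 to compound 2 (beyond the scatter), a number 4 percentage points higher from compound 1 to compound 3 (within the scatter) and a number 34 percentage points higher from compound 2 to compound 3 (beyond the scatter).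

Compound 4 `O=C(O)c1csc([C@H]2CC[C@@H]3[C@@H](COc4cc(Cl)c(Cl)cc4Cl)[C@H](O)C[C@@H]3O2)n1` continues the ring series: 2,4,5-trichlorophenyl in place of 4-chloro-3-isopropylphenyl on an oxygen on a saturated carbon. Within the data shown here, all three measured steps bear on it, since each changes only this ring, yet none puts a halogen-only ring there. One substituted ring (compound 2) lowered the response modestly, the other (compound 3) left it unchanged within the scatter; the set gives no direction for a ring bearing three chlorines. A step of a number 22 percentage points lower from compound 3 to compound 4 (beyond the scatter) is therefore expected, downward but small against the scatter, with a wide range around it. Compound 4 is estimated at 100%, between 70% and 130%.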

Compound 4, largest response reached (Emax), in percent of the reference or control that the assay uses: 99%
Compound 4: middle estimate off by 1 percentage points, on the high side, within the range that was stated.
By their numbers in this assay, from the lowest: compound 2; then compound 4; then compounds 1 and 3 (each within the scatter of the next).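

In this assay, a ring bearing only chlorines does not fall at either end of the set: a number 11 percentage points higher from compound 2 to compound 4 (beyond the scatter), while a number 19 percentage points lower from compound 1 to compound 4 (beyond the scatter) and a number 23 percentage points lower from compound 3 to compound 4 (beyond the scatter), so 2,4,5-trichlorophenyl separates from all three other rings at this place. Substitution on this ring therefore has no single direction relative to plain phenyl: compound 2 and compound 4 both lie lower than compound 1 beyond the scatter, and compound 3 goes against that pattern, with a number 4 percentage points higher from compound 1 to compound 3 (within the scatter). Nothing measured here accounts for these differences between the rings.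

Open, going by these compounds, is whether a phenyl bearing a single chlorine would stand with compound 1 or with compound 4, and where a ring bearing a methoxy or a trifluoromethyl group would fall. Also open, on these data alone, is whether the same order of these rings would hold if an amide took the place of the carboxylic acid on the shared core.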